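The source may report more compounds than this note shows. Statements on the series, on what has been measured and on what is new or still open speak of the compounds shown alone.

Of the compounds shown here, two have been measured so far in a functional assay on MCF7 cells (Homo sapiens) for cytotoxicity, read by MTT assay, with a stated time of 48 h; on this read-out higher numbers stand for weaker inhibition and lower numbers for stronger inhibition. Compound 1 `CCOc1ccc(-c2nnc(SCCn3c([N+](=O)[O-])cnc3C)o2)cc1` gives 16600 nM. Going by the values given here, compound 2 `Cc1ncc([N+](=O)[O-])n1CCSc1nnc(-c2ccc(F)cc2)o1` gives 8100 nM, the lowest of the two numbers, and the only step recorded is a 2.0-fold lower number from compound 1 to compound 2 (0.31 log units; beyond the scatter), a modest movement that came from swapping one substituent for another on the outer ring. Compound 3 `Cc1ncc([N+](=O)[O-])n1CCSc1nnc(-c2ccnc(Cl)c2)o1` has not yet been measured. It differs from compound 2 in one place: 2-chloropyridin-4-yl in place of 4-fluorophenyl on an aromatic carbon. The exchange happens on an aromatic carbon of a five-membered aromatic ring with 2 nitrogen and 1 oxygen, the same carbon that carried the 4-fluorophenyl in compound 2. Among the compounds with values here, no measured step covers the replacement of a whole ring by another ring, so the only guidance is that the single change made so far at this outer position shifted the read-out only modestly. A step of similar size, or none beyond the scatter, is therefore expected here. For compound 3 the value expected in this assay is 8000 nM, with a range from 3000 nM to 22000 nM. This estimate means an expected step of a 1.0-fold lower number from compound 2 to compound 3 (0.01 log units; within the scatter), close to the scatter of the measurement.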

Compound 3, half-maximal inhibitory concentration: 40500 nM
Estimate against measurement, compound 3: 5.1-fold (0.70 log units) below, and the stated range ends below it.
By their numbers in this assay, from the lowest: compound 2; then compound 1; then compound 3.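

In this assay, putting 2-chloropyridin-4-yl in place of 4-fluorophenyl gives a 5.0-fold higher number from compound 2 to compound 3 (0.70 log units; beyond the scatter), which shows that this carbon of the five-membered ring responds to the exchange of a whole ring, even though both groups hold the same number of heavy atoms. The direction is opposite to that of the earlier change on the outer ring, a 2.0-fold lower number from compound 1 to compound 2 (0.31 log units; beyond the scatter), so the outer group can move the number either way and the fluorinated ring remains the better of the two rings compared directly here. Several things change at once in this exchange, a ring carbon gives way to a ring nitrogen and fluorine gives way to chlorine, and nothing measured on these compounds explains the step or assigns it to either part.

On these data alone, a 4-chlorophenyl group and a plain pyridin-4-yl group at this carbon would tell the effect of the chlorine apart from that of the ring nitrogen, and how either would read remains open. Also open, as far as these compounds go, is how an amine or a carboxylic acid on the outer ring would change the number.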